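Phenyl for Methyl on the Aromatic Carbon

A few compounds are considered here, and "the series" means these few. Any claim that something is new, unique, unknown or untested is made for them only; others in the source may bear on it.

Compound 1 `CC(C)(C)NCC(O)COc1ncns1`: 70%
Compound 2 `Cc1nsc(OCC(O)CNC(C)(C)C)n1`: 39.5%

In a functional assay on the whole organism (heart, strain mongrel) for inhibition, with Canis familiaris (Canis lupus familiaris) as the target, with a stated time of 20 min, at a dose of 1.42 mg/kg by the intravenous route (on this read-out lower numbers stand for a weaker effect and higher numbers for a stronger effect at the one dose given), compound 2 gives the lower of the two numbers shown, with compound 1 as its only neighbour; the step of a number 30.5 percentage points lower from compound 1 to compound 2 (beyond the scatter) is large and beyond the scatter. Compound 3 `CC(C)(C)NCC(O)COc1nc(-c2ccccc2)ns1` is the next step from compound 2: phenyl in place of methyl on an aromatic carbon. Within the data shown here, no measured pair repeats this exchange, so the only step that bears on it is a number 30.5 percentage points lower from compound 1 to compound 2 (beyond the scatter), in which a larger group at this aromatic carbon went with a clear fall in inhibition. On that single precedent a further fall, or at most no change beyond the scatter, is expected rather than a recovery, and the estimated step of a number 14.5 percentage points lower from compound 2 to compound 3 (beyond the scatter) points downward. Compound 3 is therefore expected to give about 25%, within a range from 5% to 50%.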

Compound 3, a percentage reported as inhibition, in the whole organism at one dose (the size of the read-out at that dose, not a potency): 9.5%
Beside the measured number, compound 3's estimate is 15.5 percentage points above it; the range from low to high includes it.
By their numbers in this assay, from the lowest: compound 3; then compound 2; then compound 1.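

In this assay the aromatic carbon between two ring nitrogen atoms shows a second fall, a number 30 percentage points lower from compound 2 to compound 3 (beyond the scatter) and so the loss seen with methyl continues with phenyl. Taken whole, the exchange of hydrogen for phenyl gives a number 60.5 percentage points lower from compound 1 to compound 3 (beyond the scatter) and places the three listed compounds in the order hydrogen, methyl, phenyl, with none of them going against this trend. Nothing measured here accounts for this fall.

The compounds shown leave open whether the fall follows the number of heavy atoms at this carbon or belongs to the phenyl ring itself, a question that an ethyl or a cyclohexyl group there could separate. They also leave open how an amine or a carboxylic acid at this carbon would read at this one dose.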